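The source may report more compounds than this note shows. Statements on the series, on what has been measured and on what is new or still open speak of the compounds shown alone.

In an in vitro ADME assay on microsomes from liver (Homo sapiens) for metabolic stability (a higher number here means faster removal of the compound, a lower number slower removal), compound 3 (`CC(C)Nc1nccc(-c2c[nH]nc2-c2ccc(Cl)cc2)n1`) gives 0.106 mL/min/kg. Compound 1 (`Clc1ccc(-c2n[nH]cc2-c2ccnc(NC3CC3)n2)cc1`) gives 0.096 mL/min/kg, within the scatter of compound 3, while compound 2 (`OC1CCCC(c2n[nH]cc2-c2ccnc(NC3CCCC3)n2)C1`) lies clearly lower at 0.015 mL/min/kg.

Compound 4 (`Clc1ccc(-c2n[nH]cc2-c2ccnc(NC3CCCC3)n2)cc1`) has not been measured yet. It differs from compound 3 in one place, with cyclopentyl in place of isopropyl on a nitrogen on an aromatic ring.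

Within the data shown here, only one measured step changes a group at this same place. It is a 1.1-fold higher number from compound 1 to compound 3 (0.04 log units; within the scatter), with isopropyl in place of cyclopropyl, and it stays within the scatter. Among the measured compounds shown here, compound 2 also carries cyclopentyl, but no measured step connects it to the other compounds, so its value of 0.015 mL/min/kg only widens the expected range on the low side.

A change beyond the scatter is therefore not expected, and the expected step is a 1.1-fold lower number from compound 3 to compound 4 (0.03 log units; within the scatter). For compound 4 the estimate is 0.1 mL/min/kg, with an expected range from 0.04 mL/min/kg to 0.25 mL/min/kg.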

Compound 4, clearance: 0.116 mL/min/kg
Beside the measured number, compound 4's estimate is 1.2-fold (0.06 log units) below it; the range from low to high includes it.
By their numbers in this assay, from the lowest: compound 2; then compounds 1, 3 and 4 (each within the scatter of the next).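

With cyclopentyl on the nitrogen, a 1.1-fold higher number from compound 3 to compound 4 (0.04 log units; within the scatter) and a 1.2-fold higher number from compound 1 to compound 4 (0.08 log units; within the scatter) both stay within the scatter, so in this assay cyclopropyl, isopropyl and cyclopentyl cannot be told apart at this place when the 4-chlorophenyl group is present. Compound 4 also gives compound 2 its first measured link to the series, a 7.7-fold higher number from compound 2 to compound 4 (0.89 log units; beyond the scatter), with 4-chlorophenyl in place of 3-hydroxycyclohexyl on an aromatic carbon, so the low number of compound 2 goes with that swap and not with its cyclopentyl. No measurement shown here bears on the reason for either result.

All three groups on this nitrogen contain only carbon, so a group such as a morpholine or a longer chain could behave differently there. It also stays open whether the hydroxyl or the cyclohexyl ring matters more, as plain cyclohexyl is not among these compounds.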